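Series notes: urea aryl replacement on the shared core

The compounds below may be only part of what the source reports. "The series", "measured", "known", "first", "only" and "open" are said of these compounds alone.

Three compounds of the series carry the shared core of compound 1 `O=C(Nc1ccc(Cl)cc1)Nc1ccc(Nc2ncnc3c2OCCN3)cc1`. In an assay on isolated protein for inhibition of proto-oncogene tyrosine-protein kinase receptor Ret (Homo sapiens), read by 33P incorporation, with stated times of 15 min and 40 min (on this read-out higher numbers stand for weaker inhibition and lower numbers for stronger inhibition), compound 1 gives 3070 nM, the highest of the three numbers measured. Compound 2 `O=C(Nc1ccc(Br)cc1)Nc1ccc(Nc2ncnc3c2OCCN3)cc1` gives 2220 nM in this assay, and the step of a 1.4-fold lower number from compound 1 to compound 2 (0.14 log units; within the scatter). Compound 3 `CC(C)(C)c1cc(NC(=O)Nc2ccc(Nc3ncnc4c3OCCN4)cc2)no1` gives 10 nM in this assay; the steps of a 310-fold lower number from compound 1 to compound 3 (2.49 log units; beyond the scatter) and a 220-fold lower number from compound 2 to compound 3 (2.35 log units; beyond the scatter).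

Compound 4 `CC(C)(C)c1csc(NC(=O)Nc2ccc(Nc3ncnc4c3OCCN4)cc2)n1` is not yet measured in this assay. It differs from compound 1 in one place: 4-(tert-butyl)-1,3-thiazol-2-yl in place of 4-chlorophenyl on an amide-type nitrogen. The change resembles that from compound 1 to compound 3, where a group with one five-membered aromatic ring with 2 hetero atoms and a tert-butyl group also replaced 4-chlorophenyl on the amide-type nitrogen, and that step was large. The step from compound 1 to compound 2 does not bear on this change. The expected step is therefore of the same kind, a 200-fold lower number from compound 1 to compound 4 (2.31 log units; beyond the scatter), towards a lower number. Compound 4 is estimated at 15 nM in this assay, with a range from 4 nM to 60 nM.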

Compound 4, half-maximal inhibitory concentration: 3150 nM
Compound 4: middle estimate off by 210-fold (2.32 log units), on the low side; measured number above the stated range.
By their numbers in this assay, from the lowest: compound 3; then compounds 2, 1 and 4 (each within the scatter of the next).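

Notes on the urea aryl replacement: a five-membered aromatic ring with 2 hetero atoms and a tert-butyl group on the amide-type nitrogen does not by itself separate a compound from the halophenyl ureas in this assay. The steps are a 1.0-fold higher number from compound 1 to compound 4 (0.01 log units; within the scatter) and a 1.4-fold higher number from compound 2 to compound 4 (0.15 log units; within the scatter), so 4-(tert-butyl)-1,3-thiazol-2-yl gives no separation from 4-chlorophenyl or 4-bromophenyl, whereas 5-(tert-butyl)-1,2-oxazol-3-yl and 4-(tert-butyl)-1,3-thiazol-2-yl are far from interchangeable, with a 320-fold higher number from compound 3 to compound 4 (2.50 log units; beyond the scatter). No supporting data bear on why these two groups part so widely.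

Open, on these data alone, is whether the low number of compound 3 survives with a methyl or cyclopropyl group in place of tert-butyl on the same 1,2-oxazol-3-yl ring. Also open, as far as these compounds go, is how a 5-(tert-butyl)-1,3,4-thiadiazol-2-yl group would fall relative to these two.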